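The compounds below may be only part of what the source reports. "The series", "measured", "known", "first", "only" and "open" are said of these compounds alone.

Compound 2 `COc1cc(C(=O)NS(=O)(=O)c2ccccc2)ccc1Cn1ncc2ccc(NC(=O)CC3CCCC3)cc21` is the reference point here; in a functional assay (trachea) for antagonist activity, with Cavia porcellus as the target (a lower number here means a less potent compound, a higher number a more potent compound, by a factor of ten per unit of this negative logarithm), compound 2 gives 10.5. Compound 1 `COc1cc(C(=O)NS(=O)(=O)c2ccccc2C)ccc1Cn1ncc2ccc(NC(=O)OC3CCCC3)cc21` differs from it in more than one place, and in this assay compound 1 gives 10.2; the two numbers lie within the scatter of each other, so no order between them is claimed. Compound 3 `COc1cc(C(=O)NS(=O)(=O)c2ccccc2C)ccc1Cn1ncc2ccc(NC(=O)CC3CCCC3)cc21` is not yet measured. It differs from compound 2 only by methyl in place of hydrogen on an aromatic carbon. Within the data shown here, no measured pair isolates this single change. The step of a number 0.10 log units lower from compound 2 to compound 3 (within the scatter) is expected to stay within the scatter. For compound 3 the estimate in this assay is 10.4, with a range from 9.9 to 10.9.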

Compound 3, negative logarithm of the antagonist equilibrium constant: 10.9
For compound 3 the middle estimate is 0.50 log units below the measured one; the measured number falls inside the stated range.
By their numbers in this assay, from the lowest: compounds 1 and 2 (each within the scatter of the next); then compound 3.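

In this assay, among these compounds, the change from phenylsulfonyl to (2-methylphenyl)sulfonyl gives a number 0.40 log units higher from compound 2 to compound 3 (beyond the scatter) and is the first reading of methyl at this place on its own. With that methyl held constant, cyclopentylmethyl in place of cyclopentyloxy on a carbonyl carbon gives a number 0.70 log units higher from compound 1 to compound 3 (beyond the scatter) as a single-place comparison. No supporting measurement accounts for either step. On these data alone, whether chloro or methoxy at the same place would match methyl remains open. An ethyl group there, or methyl elsewhere on that ring, is equally unresolved.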